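The source may report more compounds than this note shows. Statements on the series, on what has been measured and on what is new or still open speak of the compounds shown alone.

Measured compounds:
- compound 1, `CCCCC[C@@H](C(=O)NCNC(=O)c1ccc(-c2cc(OCC)cc(C(=O)O)c2)o1)[C@@H](CC)N(O)C=O`: < 1 nM
- compound 2, `CCCCC[C@H](CN(O)C=O)C(=O)NCNC(=O)c1ccc(-c2ccccc2)o1`: 25 nM

Notes on the series. For the measured compounds named here, in an assay on CHO cells for inhibition of bone morphogenetic protein 1 (Homo sapiens), with stated times of 10 min and 60 min (on this read-out lower numbers stand for stronger inhibition and higher numbers for weaker inhibition), compound 2 gives 25 nM, and this is the only plain number so far. Compound 1 in this assay returns < 1 nM, which is a limit of the assay and not a number (the limit of < 1 nM in this assay, at which 1 of the 2 values shown sits). Compound 1 and compound 2 differ in several places, so the two values are set side by side without a step being drawn between them.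

The compound to be measured next is compound 3, `CCCCC[C@H](CN(O)C=O)C(=O)NCNC(=O)c1ccc(-c2cccc(C(=O)O)c2)o1`. Its difference from compound 2 is a single change: carboxy in place of hydrogen on an aromatic carbon, meta to a large group; read one bond further out, phenyl becomes 3-carboxyphenyl. Going by the values given here, no measured pair shows this change on its own.

Expectation: a step beyond the scatter, toward stronger inhibition, is expected here, of the size a 4.2-fold lower number from compound 2 to compound 3 (0.62 log units; beyond the scatter). For compound 3 in this assay the estimate is 6 nM, within 1.5 nM to 25 nM, with some chance that only a limit is reported.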

Compound 3, half-maximal inhibitory concentration: 8 nM
The estimate for compound 3 lay 1.3-fold (0.12 log units) below the measured number, within the range that was stated.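

In this assay, carboxy in place of hydrogen on an aromatic carbon, meta to a large group, gives a 3.1-fold lower number from compound 2 to compound 3 (0.49 log units; beyond the scatter) and so moves the number toward stronger inhibition. For the compounds shown here, this is the first single change that can be read, since compound 1 and compound 2 differ in several places and do not isolate the move from phenyl to 3-carboxyphenyl. Compound 1 also carries a carboxy group on its six-membered aromatic ring, but its value is a limit of the assay and not a number: the limit of < 1 nM in this assay, at which 1 of the 3 values shown sits.

The compounds shown leave open whether the step belongs to the carboxylic acid itself or would also appear with another group at this place, such as a primary amide, a methyl ester or an amine. They also leave open how much the ethoxy group on the aromatic ring of compound 1, or the extra ethyl group on its chain, contributes on its own when set beside the 3-carboxyphenyl group of compound 3.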